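This account rests on a few compounds, and the source may have more. Where it says the series, first, only, none or still open, it means among the compounds named here.

Measured so far in an in vitro assay on 293-EBNA cells for binding affinity to corticotropin-releasing factor receptor 1 (Homo sapiens); on this read-out lower numbers stand for stronger inhibition and higher numbers for weaker inhibition:
- compound 1 `CCC(Nc1nc(C)nc2c1nnn2-c1ccc(C(C)C)cc1Br)C(=O)OC`: 19.4 nM
- compound 2 `CCCCNc1nc(C)nc2c1nnn2-c1ccc(C(C)C)cc1Br`: 69.6 nM

Compound 2 holds the higher of these two numbers; its nearest neighbour is compound 1, and the step of a 3.6-fold higher number from compound 1 to compound 2 (0.55 log units; beyond the scatter) shows that exchanging the branched ester-bearing chain for a plain butyl chain weakened binding. Compound 3 `CCC(COC)Oc1nc(C)nc2c1nnn2-c1ccc(C(C)C)cc1Br` carries a new side chain on the shared core: 1-(methoxymethyl)propoxy in place of butylamino on an aromatic carbon. For the measured compounds named here, the only measured step, from compound 1 to compound 2, bears on this change in part, since compound 3 again has a branched chain carrying an oxygen acceptor at its first carbon, as compound 1 does; the switch from a nitrogen linker to an oxygen linker, however, has no measured counterpart here. A modest move back toward the lower number of compound 1 is therefore expected, with wide uncertainty, so that the estimated step of a 2.2-fold lower number from compound 2 to compound 3 (0.34 log units; beyond the scatter) is expected. For compound 3 the expected value in this assay is 32 nM, within a range of 8 nM to 130 nM.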

Compound 3, inhibition constant: 1.9 nM
Compound 3: middle estimate off by 17-fold (1.23 log units), on the high side, and the stated range ends above it.
By their numbers in this assay, from the lowest: compound 3; then compound 1; then compound 2.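

In this assay, putting 1-(methoxymethyl)propoxy in place of butylamino on this aromatic carbon gives a 37-fold lower number from compound 2 to compound 3 (1.56 log units; beyond the scatter) and so shows that this position accepts a chain joined through oxygen, with no hydrogen-bond donor in the group. Even against the branched ester-bearing chain, the change gives a 10-fold lower number from compound 1 to compound 3 (1.01 log units; beyond the scatter) and so shows that the hydrogen on the linking nitrogen is not needed for strong binding here. Nothing measured here explains this gain.

Both steps change the linking atom and the chain together, so the share of each stays unresolved. Going by these compounds, a plain butoxy chain or a 1-(methoxymethyl)propylamino chain on the shared core would each change only one of the two, and whether a longer chain fits here also remains open.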